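Swapping nitro for methyl: what to expect for cytotoxicity

The source may report more compounds than this note shows. Statements on the series, on what has been measured and on what is new or still open speak of the compounds shown alone.

Measured compounds:
compound 1, `CSc1nc(NCCCCNc2ccnc3cc(Cl)ccc23)c(C#N)c(-c2ccc([N+](=O)[O-])cc2)n1`, 4000 nM
compound 2, `CSc1nc(-c2ccc([N+](=O)[O-])cc2)c(C#N)c(N2CCN(c3ccnc4cc(Cl)ccc34)CC2)n1`, > 100000 nM

In an ADME assay on MDCK cells (Canis lupus familiaris) for cytotoxicity, read by microscopy (on this read-out higher numbers stand for lower toxicity in this test and lower numbers for higher toxicity in this test), compound 1 gives 4000 nM, the only plain number shown. Compound 2 reaches only a limit of this assay, > 100000 nM, so no number is known for it; this is the limit of > 100000 nM in this assay, at which 1 of the 2 values shown sits. Among the compounds with values here, no step between measured compounds is available, so the effect of any single change is unknown.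

Compound 3, `CSc1nc(NCCCCNc2ccnc3cc(Cl)ccc23)c(C#N)c(-c2ccc(C)cc2)n1`, has not been measured. It differs from compound 1 in one place: methyl in place of nitro on an aromatic carbon. Nothing measured here shows how this change moves the read-out, so the step is expected to be small, with no set direction: no change at the digits printed from compound 1 to compound 3 (within the scatter) is the expected step from compound 1 to compound 3. Compound 3 is therefore expected to give about 4000 nM in this assay, with a plausible range from 1000 nM to 20000 nM.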

Compound 3, minimum cytotoxic concentration: 20000 nM
Beside the measured number, compound 3's estimate is 5.0-fold (0.70 log units) below it; low and high end bracket the measured number.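

In this assay, within the data shown here, going from 4-nitrophenyl to 4-methylphenyl gives a 5.0-fold higher number from compound 1 to compound 3 (0.70 log units; beyond the scatter), the first single change that can be read. This shows that the group on this aromatic ring matters for the read-out, with the methyl compound looking less toxic in this test, although the nitro group is not needed for a toxic effect to be seen, since compound 3 still reaches a plain number within the assay's range. The scale extends further up, as compound 2 reaches a limit rather than a number: the limit of > 100000 nM in this assay, at which 1 of the 3 values shown sits.

With only one replacement at this position, the data cannot separate the loss of nitro from the arrival of methyl, and an amine, a chlorine atom or a carboxylic acid in the same place could help tell these apart. From the compounds shown here alone, whether the same swap would move the read-out similarly on the core of compound 2 also remains open.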